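A Ring-for-Ring Swap on a Shared Urea Core

The compounds below may be only part of what the source reports. "The series", "measured", "known", "first", "only" and "open" are said of these compounds alone.

For the measured compounds named here, compound 1 `O=C(Nc1ccc(-n2ncc3c(Br)cccc32)cc1)Nc1ccc(Cl)c(C(F)(F)F)c1` is one of only two compounds measured in a functional assay on OS-RC-2 cells (Homo sapiens) for cytotoxicity, read by MTT assay, with a stated time of 72 h (a lower number here means a stronger inhibitor, a higher number a weaker inhibitor), where compound 1 gives 9900 nM. Compound 2 `CNc1cccc2c1cnn2-c1ccc(NC(=O)Nc2ccc(Cl)c(C(F)(F)F)c2)cc1` gives 10600 nM, and the step of a 1.1-fold higher number from compound 1 to compound 2 (0.03 log units; within the scatter) shows the two numbers cannot be told apart. Compound 3 `O=C(Nc1ccc(-n2ncc3cnccc32)cc1)Nc1ccc(Cl)c(C(F)(F)F)c1` differs from compound 1 by a group of 9 heavy atoms (6 carbon, 3 nitrogen; one five-membered aromatic ring with 2 hetero atoms, one six-membered aromatic ring with 1 hetero atom) in place of a group of 10 heavy atoms (7 carbon, 2 nitrogen, 1 bromine; one five-membered aromatic ring with 2 hetero atoms, one six-membered aromatic ring of carbon only), on an aromatic carbon. No measured step covers this exchange; the only step shown, a 1.1-fold higher number from compound 1 to compound 2 (0.03 log units; within the scatter), touches a substituent on the group that leaves and stayed inside the scatter. For compound 3 the step is therefore expected to be a 1.2-fold higher number from compound 1 to compound 3 (0.08 log units; within the scatter), no more than the scatter. Compound 3 is estimated at 12000 nM, within 4000 nM to 40000 nM.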

Compound 3, half-maximal inhibitory concentration: > 32000 nM
Compound 3 was reported as a limit (the forecaster's own chance of this, stated with the estimate: 20%); at least 2.6-fold (0.42 log units) between middle value and limit.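

Unlike the earlier substituent exchange, replacing the whole 4-bromo-1H-indazol-1-yl group with one whose six-membered aromatic ring has 1 hetero atom and no bromine gives an at least 3.2-fold higher number from compound 1 to compound 3 (0.50 log units; beyond the scatter) in this assay. This position, on an aromatic carbon para to a large group, is therefore not indifferent to what sits there. The value of compound 3 is a limit, not a number: the limit of > 32000 nM in this assay, at which 1 of the 3 values shown sits.

As far as these compounds go, the size of the step beyond that limit stays open, as does the separate share of the ring nitrogen and the lost bromine. Also open, from the compounds shown here alone, is whether a fluoro or an amino group on the new six-membered ring would bring the number back towards that of compound 1.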